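The source may hold more compounds than are shown below. What is called first, only, known or untested is meant among the compounds shown, and "the series" means these compounds.

Among the three compounds measured in a functional assay on HT-29 cells (Homo sapiens) for inhibition, read by sulforhodamine B assay, with a stated time of 72 h (a higher number here means a weaker inhibitor, a lower number a stronger inhibitor), compound 3 `COc1cc(N2C(=O)C(Oc3ccccc3)C2c2ccc(SC)cc2)cc(OC)c1OC` has the highest number at 336 nM, making it the weakest inhibitor here. Compound 2 `C=CC1C(=O)N(c2cc(OC)c(OC)c(OC)c2)C1c1ccc(SC)cc1` gives 113 nM and compound 1 `CCOc1ccc(C2C(C3CC3)C(=O)N2c2cc(OC)c(OC)c(OC)c2)cc1` gives 63 nM. Compound 4 `CCOc1ccc(C2C(Oc3ccccc3)C(=O)N2c2cc(OC)c(OC)c(OC)c2)cc1` keeps the phenoxy group of compound 3 but carries ethoxy in place of methylsulfanyl on an aromatic carbon. Among the measured compounds shown here, the one measured step, a 3.0-fold higher number from compound 2 to compound 3 (0.47 log units; beyond the scatter), is a modest change at a different place, so it does not test this swap. Compound 1 carries ethoxy, but it differs from compound 2 in a second place too, so that pair gives no clean comparison. No change beyond the scatter is therefore expected. The expected result is a 1.3-fold lower number from compound 3 to compound 4 (0.13 log units; within the scatter). For compound 4 the estimated value is 250 nM, with an expected range of 85 nM to 750 nM.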

Compound 4, half-maximal inhibitory concentration: 388 nM
Estimate against measurement, compound 4: 1.6-fold (0.19 log units) below, within the range that was stated.
By their numbers in this assay, from the lowest: compounds 1 and 2 (each within the scatter of the next); then compounds 3 and 4 (each within the scatter of the next).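

In this assay, ethoxy in place of methylsulfanyl on an aromatic carbon gives a 1.2-fold higher number from compound 3 to compound 4 (0.06 log units; within the scatter), so with phenoxy on the saturated ring carbon, the two groups cannot be told apart. With ethoxy held fixed, phenoxy in place of cyclopropyl gives a 6.2-fold higher number from compound 1 to compound 4 (0.79 log units; beyond the scatter), a second clean step in which phenoxy brings a higher number, after the one from vinyl. Nothing available here explains either step.

As far as these compounds go, whether ethoxy and methylsulfanyl also match when cyclopropyl or vinyl sits on the saturated ring carbon stays open. So does the effect of an amine or a longer chain such as butoxy on the aromatic carbon.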